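A few compounds are considered here, and "the series" means these few. Any claim that something is new, unique, unknown or untested is made for them only; others in the source may bear on it.

Measured compounds:
compound 1 `Cc1ccc(NC(=O)c2cccc(C(=O)O)c2)cc1` — in an assay on isolated protein for agonist activity at Bile acid receptor (Homo sapiens), read by TR-FRET, with a stated time of 3 h, in the absence of a further agent (on this read-out lower numbers stand for an effect already at smaller amounts and higher numbers for an effect only at larger amounts of compound), compound 1 gives > 10000 nM, which is a limit of the assay rather than a number.
compound 2 `CC(C)CCOc1cccc(C(=O)Nc2cccc(C(=O)O)c2)c1` — compound 2 gives 2760 nM.
compound 3 `Cc1cccc(COc2ccc(C(=O)Nc3cccc(C(=O)O)c3)cc2)c1` — compound 3 gives 259 nM.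

Of the two numbers that are not limits, compound 2 stands at the higher one; compound 3 sits at a lower number, and the gap between them lies beyond the usual scatter. The limit for compound 1 is the one described by the limit of > 10000 nM in this assay, at which 1 of the 3 values shown sits. Compound 4 `Cc1ccccc1-c1cccc(C(=O)Nc2cccc(C(=O)O)c2)c1` differs from compound 2 in one place: 2-methylphenyl in place of isopentyloxy on an aromatic carbon. Among the measured compounds shown here, no measured pair isolates this change, so its size can only be guessed. Compared with compound 2, the number for compound 4 is expected to fall, by a step of a 2.8-fold lower number from compound 2 to compound 4 (0.44 log units; beyond the scatter), with wide uncertainty. The estimate for compound 4 is 1000 nM, in a range from 250 nM to 4000 nM.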

Compound 4, half-maximal effective concentration: 68 nM
For compound 4 the middle estimate is 15-fold (1.17 log units) above the measured one; measured number below the stated range.
By their numbers in this assay, from the lowest: compound 4; then compound 3; then compound 2. At a limit, above all of these: compound 1.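

In this assay, 2-methylphenyl in place of isopentyloxy on an aromatic carbon, meta to a large group, gives a 41-fold lower number from compound 2 to compound 4 (1.61 log units; beyond the scatter). This position therefore accepts a six-membered aromatic ring of carbon only, and the number falls even though the oxygen of the isopentyloxy group is gone. No measurement shown gives a reason for the size of this step. On these data alone, it remains open whether the ring alone or also its methyl carries the step, and how an unsubstituted phenyl, a pyridine ring or an amine would read at this place.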